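Three Analogues at the Assay Limit, a Fourth Expected There

The source may report more compounds than this note shows. Statements on the series, on what has been measured and on what is new or still open speak of the compounds shown alone.

Three compounds built on one shared core were tested in an ADME assay on Vero cells (Chlorocebus sabaeus) for cytotoxicity, read by resazurin assay, with a stated time of 3 days; a higher number here means a weaker inhibitor, a lower number a stronger inhibitor. Compound 1 `O=C(Nc1cc2nc(C3CCCCC3)[nH]c2cc1N1CCCC1)c1ccc(Br)cc1` carries a 4-bromophenyl on its carbonyl carbon and a pyrrolidin-1-yl on the aromatic ring. In this assay compound 1 gives > 100 ug/mL, which is a limit of the assay rather than a number. Compound 2 `CCOCCOC(=O)Nc1cc2nc(C3CCCCC3)[nH]c2cc1N1CCCC1` differs from compound 1 by 2-ethoxyethoxy in place of 4-bromophenyl on a carbonyl carbon. In this assay compound 2 gives > 100 ug/mL, again a limit. Compound 3 `CCN(CC)c1cc2[nH]c(C3CCCCC3)nc2cc1NC(=O)c1ccc(Br)cc1` differs from compound 1 only in its core, and the two cores differ by diethylamino in place of pyrrolidin-1-yl on an aromatic carbon. In this assay compound 3 gives > 100 ug/mL, also a limit. Because all three values sit at the limit of > 100 ug/mL in this assay, at which 3 of the 3 values shown sit, the step that the two limits leave unreadable from compound 1 to compound 2 and the step that the two limits leave unreadable from compound 1 to compound 3 cannot be sized.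

Compound 4 `CCOCCOC(=O)Nc1cc2nc(C3CCCCC3)[nH]c2cc1N(CC)CC` has not yet been measured. It differs from compound 3 by 2-ethoxyethoxy in place of 4-bromophenyl on a carbonyl carbon, the same change, at the same place, that turns compound 1 into compound 2. That earlier step ends at the limit, so the step that the limit leaves unreadable from compound 3 to compound 4 is expected to be small or unreadable in the same way. This expectation rests on compound 2, which in this assay gives > 100 ug/mL. Compound 4 is therefore estimated at 150 ug/mL, with a range from 60 ug/mL to 400 ug/mL, most likely reported only as a limit.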

Compound 4, half-maximal inhibitory concentration: > 100 ug/mL
Compound 4 ended at the assay's limit; the forecaster's own chance of this, stated with the estimate: 85%; the middle value does not contradict the limit.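

In this assay compound 4 gives > 100 ug/mL, which is a limit and not a number. No new step can be read from compound 3 or compound 2 to compound 4, because all four compounds stand at the same place: the limit of > 100 ug/mL in this assay, at which 4 of the 4 values shown sit. The compounds shown leave open whether swapping 4-bromophenyl for 2-ethoxyethoxy, or pyrrolidin-1-yl for diethylamino, changes the true value in this assay at all.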